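The source may report more compounds than this note shows. Statements on the series, on what has been measured and on what is new or still open speak of the compounds shown alone.

Measured compounds:
- compound 1 `CN1[C@@H]2c3[nH]c4ccccc4c3C[C@H]1[C@H](C#N)N1[C@@H](CNC(=O)c3ccc(Cl)cc3)c3[nH]c4ccccc4c3C[C@@H]21` gives 110 nM in a functional assay on BGC-823 cells (Homo sapiens) for cytotoxicity, read by MTT assay, with a stated time of 72 h; a lower number here means a stronger inhibitor, a higher number a weaker inhibitor
- compound 2 `COc1ccc(C(=O)NC[C@H]2c3[nH]c4ccccc4c3C[C@H]3[C@H]4c5[nH]c6ccccc6c5C[C@@H]([C@H](C#N)N23)N4C)cc1` gives 320 nM in this assay
- compound 3 `CN1[C@@H]2c3[nH]c4ccccc4c3C[C@H]1[C@H](C#N)N1[C@@H](CNC(=O)c3ccc4ccccc4c3)c3[nH]c4ccccc4c3C[C@@H]21` gives 1110 nM in this assay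

Compound 3 stands at the highest number of the three, the weakest of this small set: compound 2 lies nearest with a 3.5-fold higher number from compound 2 to compound 3 (0.54 log units; beyond the scatter), and compound 1 furthest with a 10-fold higher number from compound 1 to compound 3 (1.00 log units; beyond the scatter). The shared core of compound 3 is left untouched throughout; only the aryl group on the carbonyl carbon of the amide changes.

Compound 4 `CN1[C@@H]2c3[nH]c4ccccc4c3C[C@H]1[C@H](C#N)N1[C@@H](CNC(=O)c3ccc4ccccc4n3)c3[nH]c4ccccc4c3C[C@@H]21` takes this one step further: quinolin-2-yl in place of naphthalen-2-yl on a carbonyl carbon. For the measured compounds named here, no measured pair shows a ring nitrogen being introduced into the aryl group, so there is no step that bears directly on this change. The steps that do exist all alter the aryl group on the same carbonyl carbon and are modest: a 2.9-fold higher number from compound 1 to compound 2 (0.46 log units; beyond the scatter), a 10-fold higher number from compound 1 to compound 3 (1.00 log units; beyond the scatter) and a 3.5-fold higher number from compound 2 to compound 3 (0.54 log units; beyond the scatter). They show that changes to this aryl group move the number, but they give no direction for an exchange of one ring carbon for a nitrogen. Compound 4 is therefore expected to stay close to compound 3, with a step of a 1.1-fold lower number from compound 3 to compound 4 (0.05 log units; within the scatter) in this assay, not beyond the scatter. The estimate for compound 4 in this assay is 1000 nM, within 350 nM to 3000 nM.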

Compound 4, half-maximal inhibitory concentration: 80 nM
Compound 4: the middle estimate sits 13-fold (1.10 log units) above what was measured, and the stated range ends above it.
By their numbers in this assay, from the lowest: compounds 4 and 1 (each within the scatter of the next); then compound 2; then compound 3.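

Exchanging a single ring carbon for nitrogen in the aryl group on the carbonyl carbon, with the count of heavy atoms unchanged, gives a 14-fold lower number from compound 3 to compound 4 (1.14 log units; beyond the scatter) in this assay, so this position responds to the identity of one ring atom and not only to the choice among different aryl groups. Compound 3 and compound 4 both carry two six-membered aromatic rings, so having two rings does not by itself set the high number of compound 3: quinolin-2-yl also gives a 4.0-fold lower number from compound 2 to compound 4 (0.60 log units; beyond the scatter), while a 1.4-fold lower number from compound 1 to compound 4 (0.14 log units; within the scatter) places it with the single-ring 4-chlorophenyl group of compound 1. Nothing shown offers a measured explanation for the effect of the ring nitrogen.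

The compounds shown leave open whether a pyridin-2-yl group, which has a ring nitrogen in a single six-membered ring, would keep the number of compound 4 or lose it. From the compounds shown here alone, it also remains open whether the nitrogen must sit as it does in quinolin-2-yl, which a quinolin-3-yl group on the same carbonyl carbon would test.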